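N-Methylation of a Bridged Amine at the Alpha4/Beta2 Receptor

A few compounds are considered here, and "the series" means these few. Any claim that something is new, unique, unknown or untested is made for them only; others in the source may bear on it.

Measured compounds:
compound 1, `CN1C[C@H]2C=C(c3cccnc3)C[C@H](C2)C1`, 7660 nM
compound 2, `Fc1ccc(C2=CC3CNCC(C2)C3)cn1`, 85 nM
compound 3, `C1=C(c2cccnc2)C[C@H]2CNC[C@@H]1C2`, 12 nM

In an in vitro functional assay on SH-EP1 cells for agonist activity at Neuronal acetylcholine receptor; alpha4/beta2 (Homo sapiens), read by FLIPR and calcium flux (on this read-out higher numbers stand for an effect only at larger amounts of compound and lower numbers for an effect already at smaller amounts), compound 3 gives 12 nM, whereas compound 1 gives 7660 nM. The change between them is methyl in place of hydrogen on an amine nitrogen in a ring, and it produces a 640-fold higher number from compound 3 to compound 1 (2.81 log units; beyond the scatter). Compound 2 gives 85 nM in this assay; the difference between the core of compound 2 and the core of compound 3 is not broken down here, and the two values show that compound 2 lies beyond the scatter from both compound 3 and compound 1.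

Compound 4, `CN1CC2C=C(c3ccc(F)nc3)CC(C2)C1`, has not yet been measured. It differs from compound 2 by methyl in place of hydrogen on an amine nitrogen in a ring, the same change that leads from compound 3 to compound 1. Because a 640-fold higher number from compound 3 to compound 1 (2.81 log units; beyond the scatter) was large, a step of comparable kind and direction is expected here as well, so that compound 4 is estimated to lie at a 240-fold higher number from compound 2 to compound 4 (2.37 log units; beyond the scatter) relative to compound 2, with 3000 nM and 80000 nM as the expected bounds. Compound 4 is therefore estimated at 20000 nM in this assay.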

Compound 4, half-maximal effective concentration: > 10000 nM
Compound 4 ended at the assay's limit; the forecaster's own chance of this, stated with the estimate: 25%; the middle value does not contradict the limit.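

In this assay compound 4 gives > 10000 nM, which is a limit of the assay and not a number. Even so, the step can be read in one direction: methyl in place of hydrogen on an amine nitrogen in a ring gives an at least 110-fold higher number from compound 2 to compound 4 (2.07 log units; beyond the scatter), so on both cores shown the change goes the same way and the step is large: the same change on two cores in this assay, a 640-fold higher number (2.81 log units; beyond the scatter) from compound 3 to compound 1 and an at least 110-fold higher number (2.07 log units; beyond the scatter) from compound 2 to compound 4; the limit leaves it open whether they differ. This does not show that the change costs the same amount on each core, and two cores are too few to support a rule for the whole series, as the value of compound 4 sits at the end of the measurable range: the limit of > 10000 nM in this assay, at which 1 of the 4 values shown sits.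

The compounds shown leave open what a group other than methyl on this nitrogen, such as ethyl or a longer chain, would do on either core. They also leave open whether the step would keep its direction and size if the fluorine of compound 2 were replaced by chlorine or a methoxy group.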